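The compounds below may be only part of what the source reports. "The series", "measured", "known", "first", "only" and "open" are said of these compounds alone.

For the measured compounds named here, compound 1 `Fc1ccc(Oc2ccc3c(NCCCNCc4ccco4)ccnc3c2)cc1` stands level with its only neighbour in a physicochemical assay for acid dissociation: compound 1 gives 9.28, while compound 2 `COc1cccc(CNCCCNc2ccnc3cc(Oc4ccc(F)cc4)ccc23)c1O` gives 9.28. Going by the values given here, the single measured step, no change at the digits printed from compound 1 to compound 2 (within the scatter), swaps the group on a saturated chain carbon bound to an amine nitrogen and leaves the reading where it was. Compound 3 `COc1ccc(Oc2ccc3c(NCCCNCc4ccco4)ccnc3c2)cc1` differs from compound 1 elsewhere, namely (methoxy in place of fluoro on an aromatic carbon), the change sitting on an aromatic carbon of a six-membered aromatic ring of carbon only, para to a large group. Among the compounds with values here, no measured step touches this ring, so the one step available gives only indirect guidance, and it showed that replacing one neutral group by another did not shift the reading. The same outcome is expected here, and compound 3 is therefore estimated at 9.3, with a range from 9 to 9.6. That estimate implies an expected step of a number 0.02 log units higher from compound 1 to compound 3 (within the scatter), nothing beyond the scatter.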

Compound 3, acid dissociation constant: 9.28
Compound 3: the middle estimate sits 0.02 log units above what was measured; measured number inside the range.
By their numbers in this assay, from the lowest: compounds 1, 2 and 3 (each within the scatter of the next).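

In this assay, for the compounds shown here, this is the first look at the six-membered aromatic ring of carbon only: methoxy in place of fluoro on an aromatic carbon, para to a large group, gives no change at the digits printed from compound 1 to compound 3 (within the scatter). The earlier step touched only a saturated chain carbon bound to an amine nitrogen, so the result extends the level readings to a second site, even though the entering methoxy brings one more heavy atom and a hydrogen-bond acceptor that fluoro lacks in the count. No supporting measurement bears on what lies behind this result.

Only fluoro and methoxy are shown at this position, so it remains open whether an amine or a carboxylic acid there would also leave the reading level. The compounds also do not show which proton in these structures the reading belongs to.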